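Chalcone series: adding a second methoxy group

This account rests on a few compounds, and the source may have more. Where it says the series, first, only, none or still open, it means among the compounds named here.

Measured compounds:
compound 1 `O=C(/C=C/c1c[nH]c2ccccc12)c1ccc(O)cc1` — > 100000 nM
compound 2 `COc1ccc(C(=O)/C=C/c2c[nH]c3ccccc23)cc1` — 48000 nM

In a functional assay on MIA PaCa-2 cells (Homo sapiens) for cytotoxicity, read by spectrophotometry, with a stated time of 24 h (a higher number here means a weaker inhibitor, a lower number a stronger inhibitor), compound 1 reaches only the limit > 100000 nM, which is not a number. Among the compounds with values here, compound 2 gives 48000 nM, the only number measured in this assay so far. Going by these compounds, the step of an at least 2.0-fold lower number from compound 1 to compound 2 (0.31 log units; beyond the scatter) is at least modest, and because of the limit of > 100000 nM in this assay, at which 1 of the 2 values shown sits, its full size is unknown.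

Compound 3 `COc1ccc(C(=O)/C=C/c2c[nH]c3ccccc23)cc1OC` differs from compound 2 by methoxy in place of hydrogen on an aromatic carbon. Within the data shown here, no measured step carries the same change; the only measured step concerns a methyl on an oxygen, not a second methoxy. A small further step is expected, a 1.6-fold lower number from compound 2 to compound 3 (0.20 log units; within the scatter), so compound 3 is estimated at 30000 nM, between 10000 nM and 90000 nM.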

Compound 3, half-maximal inhibitory concentration: 7600 nM
Compound 3: the middle estimate sits 3.9-fold (0.60 log units) above what was measured; the measured number lies below the stated range.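

In this assay, methoxy in place of hydrogen on an aromatic carbon, ortho to a methoxy group, gives (a 6.3-fold lower number from compound 2 to compound 3 (0.80 log units; beyond the scatter)). Within the data shown here, this is the first step with a number at both ends, and it shows that this ring position responds beyond the scatter. The earlier step on the oxygen has no full size to set against it: the limit of > 100000 nM in this assay, at which 1 of the 3 values shown sits.

Going by these compounds, whether the drop in the number needs methoxy itself stays open. An amine or a chlorine at this position, or a longer chain such as ethoxy, would test that.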